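The source may hold more compounds than are shown below. What is called first, only, known or untested is meant among the compounds shown, and "the series" means these compounds.

Three compounds sharing one core have been followed in a physicochemical assay for metabolic stability, in phosphate buffer, at pH 7.4; a lower number here means that the compound disappears faster, a higher number that the compound lasts longer. Compound 1 `Cc1nc(C)c(C(=O)NCC(=O)Oc2ccc(-c3cc(=O)c4c(O)c(O)c(O)cc4o3)cc2)nc1C` gives > 72 h, which is a limit of the assay and not a number. Compound 2 `Cc1nc(C)c(C(=O)N[C@@H](C(=O)Oc2ccc(-c3cc(=O)c4c(O)c(O)c(O)cc4o3)cc2)C(C)C)nc1C` gives > 72 h, again a limit. Among the measured compounds shown here, compound 3 `Cc1nc(C)c(COC(=O)N[C@H](C)C(=O)Oc2ccc(-c3cc(=O)c4c(O)c(O)c(O)cc4o3)cc2)nc1C` gives 27.8 h, the only true number among the three. Compound 4 `CC[C@H](C)[C@@H](NC(=O)OCc1nc(C)c(C)nc1C)C(=O)Oc1ccc(-c2cc(=O)c3c(O)c(O)c(O)cc3o2)cc1` differs from compound 3 by sec-butyl in place of methyl on a saturated chain carbon bound to an amide-type nitrogen and a carbonyl carbon. For the measured compounds named here, the one measured step at this kind of carbon is a step that the two limits leave unreadable from compound 1 to compound 2, so it offers no size to carry over. Both of its ends sit at the limit of > 72 h in this assay, at which 2 of the 3 values shown sit. Compound 2 carries isopropyl at that carbon and still stands at the limit of > 72 h, so a shorter half-life is not expected for compound 4. A rise of modest size is expected instead, as a 2.2-fold higher number from compound 3 to compound 4 (0.33 log units; beyond the scatter). For compound 4 the estimate is 60 h, with an expected range from 28 h to 130 h.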

Compound 4, half-life: 64.8 h
Compound 4: middle estimate off by 1.1-fold (0.03 log units), on the low side; the range from low to high includes it.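

In this assay, among the compounds shown here, sec-butyl in place of methyl on a saturated chain carbon bound to an amide-type nitrogen and a carbonyl carbon gives a 2.3-fold higher number from compound 3 to compound 4 (0.37 log units; beyond the scatter) as the first step of readable size at this position. The direction of a change at this carbon is therefore now measured, in this one pair, with true numbers at both ends. The earlier pair could not show this, since both of its ends stand at a limit and not at a number: the limit of > 72 h in this assay, at which 2 of the 4 values shown sit.

From the compounds shown here alone, whether isopropyl in place of methyl would give a step of similar size with the rest of compound 3 unchanged remains open. Also open, going by these compounds, is what a longer straight chain, an amine or a carboxylic acid on this carbon would do to the half-life.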